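A few compounds are considered here, and "the series" means these few. Any claim that something is new, unique, unknown or untested is made for them only; others in the source may bear on it.

The measured compounds:
compound 1, `C=C[C@@](C)(/C=C/c1ccc(O)c(/C=C(\C)C(=O)OCC)c1)CCC=C(C)C`, > 26000 nM
compound 2, `COc1ccc(/C=C/[C@@](C)(/C=C/c2ccc(O)c(/C=C/C#N)c2)CCC=C(C)C)cc1`, > 26000 nM
compound 3, `CCOC(=O)/C(C)=C/c1cc(/C=C/[C@](C)(/C=C/c2ccc(OC)cc2)CCC=C(C)C)ccc1O`, > 26000 nM

In a functional assay on Raji cells (Homo sapiens) for cytotoxicity, with a stated time of 72 h (on this read-out higher numbers stand for an effect only at larger amounts of compound and lower numbers for an effect already at smaller amounts), compound 3 gives > 26000 nM, which is a limit of the assay and not a number. Compound 1 gives > 26000 nM, likewise a limit. Compound 2 gives > 26000 nM, again a limit. Compound 3 therefore stands nowhere in particular among the numbers shown: all three values are limits, as the limit of > 26000 nM in this assay, at which 3 of the 3 values shown sit, states, and the two steps that lead to it, a step that the two limits leave unreadable from compound 1 to compound 3 and a step that the two limits leave unreadable from compound 2 to compound 3, cannot be read because both ends are limits.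

Compound 4, `COc1ccc(/C=C/[C@@](C)(/C=C/c2ccc(O)c(/C=C/C(C)=O)c2)CCC=C(C)C)cc1`, differs from compound 3 in one place: 2-acetylethenyl in place of 2-(ethoxycarbonyl)prop-1-en-1-yl on an aromatic carbon. Neither measured step bears on this change with a readable size, and nothing in the three values shows whether any change at this position would move the read-out beyond the scatter. The expectation for compound 4 is thus an extrapolation from limits alone. The step from compound 3 to compound 4 is expected to be a step that the limit leaves unreadable from compound 3 to compound 4, and compound 4 is estimated at 30000 nM in this assay, within a range from 6000 nM to 150000 nM, with a good chance that only a limit is reported again.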

Compound 4, half-maximal effective concentration: > 26000 nM
Compound 4: a limit, no number; the forecaster's own chance of this, stated with the estimate: 70%; the middle value is on the limit's open side.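

In this assay, compound 4 gives > 26000 nM, which is a limit of the assay and not a number. The steps to compound 4 from compound 2 and compound 3 therefore cannot be read: the limit of > 26000 nM in this assay, at which 4 of the 4 values shown sit.

The compounds shown leave open whether any of these changes on the shared core moves the read-out at all.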